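Turning One Stereocentre in a Hydroxy-Bearing Amide

This account rests on a few compounds, and the source may have more. Where it says the series, first, only, none or still open, it means among the compounds named here.

Measured so far:
- compound 1 `CNC(=O)[C@@H](C)NCc1ccc(OCc2ccccc2)cc1`: 7 mg/kg
- compound 2 `CNC(=O)[C@H](C)NCc1ccc(OCc2ccccc2)cc1`: 7 mg/kg
- compound 3 `CNC(=O)[C@@H](CO)NCc1ccc(OCc2ccccc2)cc1`: 22.8 mg/kg

In a functional assay on the whole organism with Mus musculus as the target, in the maximal electroshock model (a higher number here means that more compound is needed for the effect, a lower number that less compound is needed), compound 3 gives 22.8 mg/kg, the highest number of the three, so it needs the most compound for the effect. The steps that lead to it are a 3.3-fold higher number from compound 1 to compound 3 (0.51 log units; beyond the scatter) and a 3.3-fold higher number from compound 2 to compound 3 (0.51 log units; beyond the scatter).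

The next compound is compound 4 `CNC(=O)[C@H](CO)NCc1ccc(OCc2ccccc2)cc1`. Its structural change is the two compounds have the same atoms and bonds and differ only in configuration as drawn: 1 of 1 stereo elements differ; a stereocentre at a saturated chain carbon is drawn R in compound 3 and S in compound 4.

Among the measured compounds shown here, one measured step bears directly on this change, because it is the same kind of swap from R to S at a saturated chain carbon: no change at the digits printed from compound 1 to compound 2 (within the scatter). That pair lacks the hydroxy of compound 3, however, so it is a single precedent and the range has to stay wide. No shift beyond the scatter is expected, and the estimated move is a 1.0-fold higher number from compound 3 to compound 4 (0.00 log units; within the scatter). For compound 4 the estimated value is 23 mg/kg, with an expected range of 11 mg/kg to 50 mg/kg.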

Compound 4, dose for half-maximal effect: 9.9 mg/kg
Beside the measured number, compound 4's estimate is 2.3-fold (0.37 log units) above it, outside the stated range (below it).
By their numbers in this assay, from the lowest: compounds 1, 2 and 4 (each within the scatter of the next); then compound 3.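

The swap from R to S at this saturated chain carbon can matter in this assay: with the hydroxy on the chain it gives a 2.3-fold lower number from compound 3 to compound 4 (0.36 log units; beyond the scatter), something the pair without the hydroxy did not show. Hydroxy in place of hydrogen also reads differently on the S form, where a 1.4-fold higher number from compound 2 to compound 4 (0.15 log units; within the scatter) stays within the scatter, as does a 1.4-fold higher number from compound 1 to compound 4 (0.15 log units; within the scatter), a step in which the configuration changes along with the hydroxy. This contrast with the R form is not firm, since the two hydroxy steps do not clearly separate: the same change on two cores in this assay, a 3.3-fold higher number (0.51 log units; beyond the scatter) from compound 1 to compound 3 and a 1.4-fold higher number (0.15 log units; within the scatter) from compound 2 to compound 4, 2.3-fold (0.36 log units) apart, within the scatter of two such steps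

The effect of configuration in hydroxy-bearing compounds rests on a single pair. Going by these compounds, whether a methoxy group, an amine or a longer chain at this carbon would also make the R and S forms differ remains open.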